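The compounds below may be only part of what the source reports. "The series", "measured", "known", "first", "only" and "open" are said of these compounds alone.

Measured in a functional assay on A549 cells (Homo sapiens) for cytotoxicity, read by MTT assay, with a stated time of 48 h; on this read-out lower numbers stand for an effect already at smaller amounts and higher numbers for an effect only at larger amounts of compound:

Compound 1 `CO[C@@H]1O[C@H](COc2cccc(C(C)C)c2)[C@@H](O)[C@H](O)[C@H]1Oc1ccc(OC2CCCCC2)cc1` gives 41000 nM.
Compound 2 `CO[C@@H]1O[C@H](COc2ccc(OC3CCCCC3)cc2)[C@@H](O)[C@H](O)[C@H]1Oc1ccc(C(C)C)cc1` gives 32000 nM.
Compound 3 `CO[C@H]1O[C@H](COc2ccc(C3CCCCC3)cc2)[C@@H](O)[C@H](O)[C@H]1Oc1cccc2c1CCCC2` gives 28000 nM.

Among these three, compound 1 carries the highest number, but both compound 2 and compound 3 sit close to it, and neither gap reaches beyond the usual scatter of repeated measurements. On the numbers shown, then, the three compounds cannot be told apart in this assay; all act only at large amounts of compound.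

Compound 4 `CO[C@@H]1O[C@H](COc2ccccc2C(C)C)[C@@H](O)[C@H](O)[C@H]1Oc1ccc(OC2CCCCC2)cc1` has not yet been measured. It shares every atom with compound 1, joined differently: 2-isopropylphenyl in place of 3-isopropylphenyl on an oxygen on a saturated carbon. Nothing else in the shared core moves. Within the data shown here, no measured pair in this set probes this kind of rearrangement, so there is no step to lean on. Given how little the three measured compounds differ from one another, the expected step of a 1.0-fold lower number from compound 1 to compound 4 (0.01 log units; within the scatter) is no larger than the scatter, with no clear direction. Compound 4 is therefore estimated at about 40000 nM, with a likely range from 20000 nM to 80000 nM.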

Compound 4, half-maximal effective concentration: 41000 nM
Compound 4: the middle estimate sits 1.0-fold (0.01 log units) below what was measured; low and high end bracket the measured number.
By their numbers in this assay, from the lowest: compounds 3, 2, 1 and 4 (each within the scatter of the next).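

Among these compounds, compound 1 and compound 4 give the first pair here that differs in one place, so this position can now be read directly. In this assay, putting 2-isopropylphenyl in place of 3-isopropylphenyl on an oxygen on a saturated carbon gives no change at the digits printed from compound 1 to compound 4 (within the scatter), so moving the isopropyl group around this ring, using the same atoms, leaves the read-out where it was. This holds for this one swap on the core of compound 1 and cannot be stretched to other groups or to other places on the molecule.

Nothing shown offers a reason for this flat result. Still open, going by these compounds, is whether a different group in place of the isopropyl, such as an amine or a carboxylic acid, would move the number beyond the scatter.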